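The source may report more compounds than this note shows. Statements on the series, on what has been measured and on what is new or still open speak of the compounds shown alone.

The measure throughout is a functional assay on the whole organism with Mus musculus as the target, with a stated time of 20 min; on this read-out lower numbers stand for an effect already at smaller amounts and higher numbers for an effect only at larger amounts of compound. Among the compounds with values here, compound 1, `CCC(=O)N[C@H]1CC[C@H](NS(=O)(=O)c2ccc(F)cc2)CC1`, gives 1 mg/kg in this assay, the highest number among the three compounds measured so far. Within the data shown here, its mirror image, compound 2, `CCC(=O)N[C@H]1CC[C@@H](NS(=O)(=O)c2ccc(F)cc2)CC1`, gives 0.1 mg/kg in this assay, and the step of a 10-fold lower number from compound 1 to compound 2 (1.00 log units; beyond the scatter) is the only change at a single place that has been measured; the two values are set apart by nothing but the configuration, because of the fact that compounds 1 and 2 differ only in the configuration as drawn. Compound 3, `CC(=O)NC1CCN(S(=O)(=O)c2ccc(F)cc2)CC1`, built on a different core, gives 0.01 mg/kg in this assay.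

The unmeasured compound 4, `CC(=O)N[C@H]1CC[C@H](NS(=O)(=O)c2ccc(F)cc2)CC1`, differs from compound 1 by hydrogen in place of methyl on a saturated chain carbon bound to a carbonyl carbon. Among the measured compounds shown here, no measured step touches this kind of change: the one step, from compound 1 to compound 2, concerns configuration alone and says nothing about ethyl to methyl on the carbonyl. Compound 3 carries the acetamido group too, but its core also differs, so its value cannot be read as the effect of that group alone. With no guide from the measured steps, the expectation is a step that stays within the usual scatter, namely a 1.4-fold lower number from compound 1 to compound 4 (0.15 log units; within the scatter). Compound 4 is therefore estimated at 0.7 mg/kg in this assay, with a range from 0.2 mg/kg to 3 mg/kg.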

Compound 4, minimum effective dose: 10 mg/kg
Compound 4: the middle estimate sits 14-fold (1.15 log units) below what was measured; measured number outside the range, above it.
By their numbers in this assay, from the lowest: compound 3; then compound 2; then compound 1; then compound 4.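

In this assay, the change from propanoylamino to acetamido, with hydrogen in place of methyl on a saturated chain carbon bound to a carbonyl carbon, gives a 10-fold higher number from compound 1 to compound 4 (1.00 log units; beyond the scatter) and so moves the number the other way from the change in configuration (a 10-fold lower number from compound 1 to compound 2 (1.00 log units; beyond the scatter)). This shows that the amide chain is a sensitive place on the core of compound 1: losing one carbon there, with the rest of the molecule untouched, shifts the dose needed by as much as inverting the stereocentres does. Nothing known about these compounds explains why the ethyl group serves better here than the methyl group.

From the compounds shown here alone, it remains open whether a longer chain at this place, such as the butanoyl group, would lower the number further or raise it again, and how an amine on the same chain would compare. Going by these compounds, it is also open whether the change from propanoyl to acetyl would give a step of similar size and direction in the configuration of compound 2, so this result holds only for the pair in which it was seen.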